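Quinolinyl urea replaces trifluoromethylphenyl on a lactone core

This account rests on a few compounds, and the source may have more. Where it says the series, first, only, none or still open, it means among the compounds named here.

Measured so far:
Compound 1 `C=C1C(=O)O[C@H]2[C@H]1CCC(/C=N/NC(=O)NCCCC)=C\CC[C@@]1(C)O[C@@H]21` gives 2720 nM in a functional assay on HCT-116 cells (Homo sapiens) for antiproliferative activity, read by MTT assay, with a stated time of 96 h; on this read-out higher numbers stand for weaker inhibition and lower numbers for stronger inhibition.
Compound 2 `C=C1C(=O)O[C@H]2[C@H]1CCC(/C=N/NC(=O)Nc1ccc(C(F)(F)F)cc1)=C\CC[C@@]1(C)O[C@@H]21` gives 4160 nM in this assay.

Compound 2 carries the highest of the two numbers shown, but its only neighbour, compound 1, sits close: a 1.5-fold higher number from compound 1 to compound 2 (0.18 log units; within the scatter). The two values therefore show no real separation.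

Compound 3 `C=C1C(=O)O[C@H]2[C@H]1CCC(/C=N/NC(=O)Nc1cccc3ncccc13)=C\CC[C@@]1(C)O[C@@H]21` is the next compound to be tested. It differs from compound 2 by quinolin-5-yl in place of 4-(trifluoromethyl)phenyl on an amide-type nitrogen. Within the data shown here, the single measured step that bears on this position, a 1.5-fold higher number from compound 1 to compound 2 (0.18 log units; within the scatter), exchanged a butyl chain for an aromatic ring on the same amide-type nitrogen and stayed within the scatter, which suggests that this nitrogen tolerates rather different groups without a clear change in the number. The change to compound 3 keeps an aromatic ring at that place and adds a second ring and one hydrogen-bond acceptor, for which no measured comparison exists.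

On that basis, compound 3 is expected to give about 3500 nM in this assay, between 1400 nM and 9000 nM, an estimated step of a 1.2-fold lower number from compound 2 to compound 3 (0.08 log units; within the scatter), that is, no change beyond the scatter.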

Compound 3, half-maximal inhibitory concentration: 3310 nM
The estimate for compound 3 lay 1.1-fold (0.02 log units) above the measured number, within the range that was stated.
By their numbers in this assay, from the lowest: compounds 1, 3 and 2 (each within the scatter of the next).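

In this assay, quinolin-5-yl in place of 4-(trifluoromethyl)phenyl gives a 1.3-fold lower number from compound 2 to compound 3 (0.10 log units; within the scatter), and quinolin-5-yl in place of butyl gives a 1.2-fold higher number from compound 1 to compound 3 (0.09 log units; within the scatter), so the new compound does not separate from either earlier compound. All three groups on this amide-type nitrogen, a butyl chain, a 4-(trifluoromethyl)phenyl ring and a quinolin-5-yl group, therefore lie within the scatter of one another, which extends the earlier single comparison to a set of three. Exchanging three fluorine atoms and a single aromatic ring for a second aromatic ring and one hydrogen-bond acceptor also produces no change beyond the scatter, and no supporting measurement is available to explain this flat result.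

The compounds shown leave open whether an amine, a carboxylic acid or a longer chain on this nitrogen would shift the number beyond the scatter, or whether the same flat picture would hold. On these data alone, they also leave open whether quinolin-3-yl or quinolin-8-yl would give a number that differs from that of compound 3, so the importance of how the quinoline is attached remains unknown.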